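The compounds below may be only part of what the source reports. "The series", "measured", "known", "first", "only" and "open" are said of these compounds alone.

In an ADME assay on Huh-7 cells (Homo sapiens) for cytotoxicity, read by fluorescence, with a stated time of 3 days (on this read-out higher numbers stand for lower toxicity in this test and lower numbers for higher toxicity in this test), compound 2 `CN(CCO)N(c1cc(C#CC(C)(C)C)sc1C(=O)O)C(=O)[C@H]1CC[C@H](C)CC1` gives > 44000 nM, which is a limit of the assay rather than a measured number. Its close relative compound 1 `CN(C)N(c1cc(C#CC(C)(C)C)sc1C(=O)O)C(=O)[C@H]1CC[C@H](C)CC1` gives > 44000 nM in this assay, again a limit. Between the two lies a step that the two limits leave unreadable from compound 1 to compound 2, and because both values sit at the limit of > 44000 nM in this assay, at which 2 of the 2 values shown sit, nothing can be said about the size of that step. Compound 3 `CN([C@H]1CC[C@H](O)CC1)N(c1cc(C#CC(C)(C)C)sc1C(=O)O)C(=O)[C@H]1CC[C@H](C)CC1` carries the change (4-hydroxycyclohexyl in place of 2-hydroxyethyl on an amine nitrogen). Among the measured compounds shown here, the only measured step that bears on this change is the one from compound 1 to compound 2, and it has no readable size, so no movement beyond the usual scatter is expected in this assay. The expected step is therefore small, a step that the limit leaves unreadable from compound 2 to compound 3. For compound 3 the estimated value in this assay is 60000 nM, with a range from 30000 nM to 150000 nM, and the result is most likely to be reported once more only as a limit.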

Compound 3, half-maximal cytotoxic concentration: > 44000 nM
Compound 3: only a limit was reported (the forecaster's own chance of this, stated with the estimate: 80%); the middle value does not contradict the limit.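

No step can be read among compound 1, compound 2 and compound 3, because each is reported only as a limit: the limit of > 44000 nM in this assay, at which 3 of the 3 values shown sit. In this assay the compounds shown leave open whether 4-hydroxycyclohexyl in place of 2-hydroxyethyl or methyl changes the read-out at all.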